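Carboxy for hydroxyethyl on the sulfonamide chain

The source may hold more compounds than are shown below. What is called first, only, known or untested is meant among the compounds shown, and "the series" means these compounds.

compound 1 `CCc1c(Cl)cc2[nH]c(=O)c(=O)[nH]c2c1N(CCO)S(C)(=O)=O`: 183 ng.h/mL
compound 2 `CS(=O)(=O)N(CCCO)c1c(Cl)c(Cl)cc2[nH]c(=O)c(=O)[nH]c12`: 136 ng.h/mL
compound 3 `Cc1c(Cl)cc2[nH]c(=O)c(=O)[nH]c2c1N(CCO)S(C)(=O)=O`: 605 ng.h/mL

In an ADME assay on the whole organism (plasma, strain Sprague-Dawley) for pharmacokinetics, with Rattus norvegicus as the target, at a dose of 5 mg/kg by the oral route (on this read-out lower numbers stand for lower exposure and higher numbers for higher exposure at the dose given), compound 2 gives the lowest of the three numbers, though compound 1 lies within the scatter of it; only compound 3 stands beyond it. For the measured compounds named here, the single one-place step among the measured compounds, a 3.3-fold higher number from compound 1 to compound 3 (0.52 log units; beyond the scatter), concerns a methyl on the aromatic ring and does not touch the chain on the sulfonamide nitrogen. Compound 4 `CS(=O)(=O)N(CC(=O)O)c1c(Cl)c(Cl)cc2[nH]c(=O)c(=O)[nH]c12` differs from compound 2 by carboxy in place of 2-hydroxyethyl on a saturated chain carbon bound to a sulfonamide nitrogen. Going by the values given here, no measured step bears on this change, so the data give no direction for it; a step within the scatter is as plausible as one beyond it either way. Compound 4 is therefore expected close to its parent, estimated at 150 ng.h/mL with a range of 40 ng.h/mL to 550 ng.h/mL, which means an expected step of a 1.1-fold higher number from compound 2 to compound 4 (0.04 log units; within the scatter).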

Compound 4, area under the concentration-time curve in the Rattus norvegicus assay: 393 ng.h/mL
Compound 4: middle estimate off by 2.6-fold (0.42 log units), on the low side; the measured number falls inside the stated range.
By their numbers in the Rattus norvegicus assay, from the lowest: compounds 2 and 1 (each within the scatter of the next); then compounds 4 and 3 (each within the scatter of the next).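

For the compounds shown here, in the Rattus norvegicus assay the chain on the sulfonamide nitrogen proves to matter: carboxy in place of 2-hydroxyethyl gives a 2.9-fold higher number from compound 2 to compound 4 (0.46 log units; beyond the scatter) and is the first step read at this place. In a physicochemical assay for solubility (on this read-out higher numbers stand for higher solubility and lower numbers for lower solubility), compound 2 gives 76 ug/mL and compound 4 gives 76 ug/mL so this read-out does not separate the two. Nothing measured here accounts for the difference in exposure.

The compounds shown leave open how an amine or a longer chain ending in carboxy would fare on the sulfonamide nitrogen. From the compounds shown here alone, whether the change carries over to the cores of compound 1 and compound 3 also remains open.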